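The compounds below may be only part of what the source reports. "The series", "measured", "known", "first", "only" and "open" are said of these compounds alone.

In a functional assay on U-87MG ATCC cells for inhibition, with U-87 MG (Homo sapiens) as the target, read by MTT assay, with a stated time of 72 h (a lower number here means a stronger inhibitor, a higher number a weaker inhibitor), the starting point is compound 1 `COc1ccc(C(Nc2cc(C)ccn2)c2ccc3cccnc3c2O)cc1O`. Compound 1 gives > 10000 nM, which is a limit of the assay and not a number. Compound 2 `Cc1ccc(C(Nc2ccccn2)c2ccc3cccnc3c2O)cc1` gives > 10000 nM, which is also a limit. The measurements so far therefore amount to the limit of > 10000 nM in this assay, at which 2 of the 2 values shown sit.

Compound 3 `Cc1ccnc(NC(c2cccc(F)c2)c2ccc3cccnc3c2O)c1` differs from compound 1 in one place: it has 3-fluorophenyl in place of 3-hydroxy-4-methoxyphenyl on a saturated chain carbon bound to an aromatic carbon and a nitrogen on an aromatic ring. Within the data shown here, no pair of measured compounds shows what a single change does here, so the estimate has little to rest on. No step beyond the usual scatter is expected, and the estimated change is a number no higher from compound 1 to compound 3 (the limit leaves the size open). For compound 3, the expected half-maximal inhibitory concentration is 10000 nM, within an estimated range of 3000 nM to 30000 nM.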

Compound 3, half-maximal inhibitory concentration: 9200 nM
Beside the measured number, compound 3's estimate is 1.1-fold (0.04 log units) above it, within the range that was stated.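

In this assay compound 3 gives 9200 nM, the first value among the compounds shown that is a number and not a limit. Compound 1 gives > 10000 nM, which is a limit of the assay. The change of 3-hydroxy-4-methoxyphenyl to 3-fluorophenyl on the saturated chain carbon gives an at least 1.0-fold lower number from compound 1 to compound 3 (0.03 log units; that floor lies within the scatter), so a readable value remains possible at this position without the hydrogen-bond donor and acceptors of the leaving group, but the true size of the step cannot be read because the starting value is capped: the limit of > 10000 nM in this assay, at which 2 of the 3 values shown sit.

Going by these compounds, it remains open whether an amine, a carboxylic acid or a longer chain on this phenyl ring would bring the number clearly lower. On these data alone, it is also open whether 3-fluorophenyl would give a readable value on the core of compound 2.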